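A few compounds are considered here, and "the series" means these few. Any claim that something is new, unique, unknown or untested is made for them only; others in the source may bear on it.

Measured so far in an assay on microsomes from intestine for inhibition of acyl-CoA:cholesterol acyltransferase (Oryctolagus cuniculus); a lower number here means a stronger inhibitor, a higher number a weaker inhibitor:
compound 1 `CC(C)c1cccc(C(C)C)c1NC(=O)NCc1ccccc1`, 360 nM
compound 2 `CC(C)c1cccc(C(C)C)c1NC(=O)NCCCc1ccccc1`, 191 nM
compound 3 `O=C(NCC1(c2ccccc2)CCCCC1)Nc1ccccc1`, 2300 nM

Compound 3 carries the highest number of the three in this assay; compounds 1 and 2 both sit well below it, and the gaps from compound 3 to each of them lie beyond the scatter. Going by the values given here, the only step between two compounds that differ in one place is a 1.9-fold lower number from compound 1 to compound 2 (0.28 log units; within the scatter), which concerns the carbon chain on the other nitrogen of the urea and stays within the scatter.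

Compound 4 `O=C(NCC1(c2ccccc2)CCCCC1)Nc1cc(Cl)ccc1Cl` is not yet measured. It differs from compound 3 in one place: 2,5-dichlorophenyl in place of phenyl on an amide-type nitrogen. Among the compounds with values here, no measured pair changes the group on this amide-type nitrogen, so no step bears directly on it. The step from compound 1 to compound 2 touches a different part of the molecule and gives no guide here. Within the data shown here, compounds 1 and 2, which carry a different aryl on the amide-type nitrogen, show lower numbers than compound 3, but with no single-change pair their values can only be noted, not converted into an expectation for compound 4.

The expectation for compound 4 is therefore a lower number than compound 3, by a 2.3-fold lower number from compound 3 to compound 4 (0.36 log units; beyond the scatter), with wide uncertainty. Compound 4 is estimated at 1000 nM, within 250 nM to 4000 nM.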

Compound 4, half-maximal inhibitory concentration: 2700 nM
Estimate against measurement, compound 4: 2.7-fold (0.43 log units) below; the range from low to high includes it.
By their numbers in this assay, from the lowest: compounds 2 and 1 (each within the scatter of the next); then compounds 3 and 4 (each within the scatter of the next).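

In this assay, 2,5-dichlorophenyl in place of phenyl on the amide-type nitrogen gives a 1.2-fold higher number from compound 3 to compound 4 (0.07 log units; within the scatter), so this change leaves the number unmoved within the scatter. Going by these compounds alone, this is the first pair that changes only the group at this position, and it shows that, on this core, the two added chlorine atoms bring no measurable gain or loss in this assay. No measurement of any other kind accompanies the pair, so nothing here accounts for the flat result.

Going by these compounds, with a single pair at this position, it remains open whether the flat result extends to other groups on that amide-type nitrogen, such as methoxyphenyl or pyridyl in place of phenyl, or to a single chlorine on the phenyl. Within the data shown here, it is also open whether the aryl of compounds 1 and 2 would lower the number on this core, and whether 2,5-dichlorophenyl would behave the same way on the core of compounds 1 and 2, since no single-change pair links these compounds to compound 3 or compound 4.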